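The source may hold more compounds than are shown below. What is called first, only, known or untested is meant among the compounds shown, and "the series" means these compounds.

In a functional assay on KB cells (Homo sapiens) for antiproliferative activity, read by MTT assay, with a stated time of 48 h (a lower number here means a stronger inhibitor, a higher number a weaker inhibitor), compound 1, `Cn1cc(C2=C(c3nn(CCCn4cccc4)c4ncccc34)C(=O)NC2=O)c2ccccc21`, gives > 100000 nM, which is a limit of the assay and not a number. Compound 2, `Cn1cc(C2=C(c3nn(CCCN4CCCCC4)c4ncccc34)C(=O)N(c3ccccn3)C2=O)c2ccccc21`, which carries piperidin-1-yl on its chain, gives > 100000 nM, also a limit. On these data alone, compound 3, `CN1CCN(CCCn2nc(C3=C(c4cn(C)c5ccccc45)C(=O)NC3=O)c3cccnc32)CC1`, gives > 100000 nM, again a limit, so its true position on the scale is unknown. Compound 4, `Cn1cc(C2=C(c3nn(CCCN4CCCCC4)c4ncccc34)C(=O)NC2=O)c2ccccc21`, is still to be measured, and it has piperidin-1-yl in place of 4-methylpiperazin-1-yl on a saturated chain carbon, three bonds along the chain from an aromatic nitrogen.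

For the measured compounds named here, only one measured step bears on this place in the chain, a step that the two limits leave unreadable from compound 1 to compound 3, so it offers no size to carry over. No clear gain or loss is expected because of the limit of > 100000 nM in this assay, at which 3 of the 3 values shown sit. The estimated change, a number no higher from compound 3 to compound 4 (the limit leaves the size open), is expected to stay within the usual scatter and has no expected direction. For compound 4, the expected value is 100000 nM, with an estimated range from 30000 nM to 150000 nM.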

Compound 4, half-maximal inhibitory concentration: 98000 nM
The estimate for compound 4 lay 1.0-fold (0.01 log units) above the measured number; the range from low to high includes it.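

In this assay, for the compounds shown here, compound 4 gives 98000 nM, the first value in this set that is a number and not a limit. Placing piperidin-1-yl in place of 4-methylpiperazin-1-yl gives an at least 1.0-fold lower number from compound 3 to compound 4 (0.00 log units; that floor lies within the scatter), hydrogen in place of pyridin-2-yl on the amide-type nitrogen gives an at least 1.0-fold lower number from compound 2 to compound 4 (0.00 log units; that floor lies within the scatter), and piperidin-1-yl in place of 1H-pyrrol-1-yl gives an at least 1.0-fold lower number from compound 1 to compound 4 (0.00 log units; that floor lies within the scatter). These steps can be given only as floors, so no real gain is shown at either place, because the other three compounds stand at a limit and not at a number: the limit of > 100000 nM in this assay, at which 3 of the 4 values shown sit.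

On these data alone, whether any change at the end of this chain can clearly lower the number remains open. A morpholine or a primary amine at the chain end, or a longer chain, would bear on that question.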